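From Chloro-Methoxy to Hydroxy-Methyl on the Pyrimidinyl Ring

The compounds below may be only part of what the source reports. "The series", "measured", "known", "first", "only" and "open" are said of these compounds alone.

Three compounds sharing one core were tested in a functional assay on the whole organism for inhibition, with Digitaria ciliaris as the target, with a stated time of 72 h, tested at 100 mg/L; on this read-out lower numbers stand for less inhibition of growth and higher numbers for more inhibition of growth at the one concentration tested. Compound 1, `COc1cc(Cl)nc(NC(=S)NC(=O)c2c(-c3ccc(Cl)cc3Cl)noc2C)n1`, gives 62.2%. Compound 2, `Cc1onc(-c2ccc(Cl)cc2Cl)c1C(=O)/N=c1/nc2nc(Cl)cc(C)n2s1`, gives 68.1%, a number within the scatter of that of compound 1. Compound 3, `COc1cc(OC)n2s/c(=N\C(=O)c3c(-c4ccc(Cl)cc4Cl)noc3C)nc2n1`, gives 85.3%, a number beyond the scatter above compound 1. Among the compounds with values here, no pair of these three differs in a single place, so no measured step can guide a prediction.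

Compound 4, `Cc1cc(O)nc(NC(=S)NC(=O)c2c(-c3ccc(Cl)cc3Cl)noc2C)n1`, has not been measured. It differs from compound 1 in one place: 4-hydroxy-6-methylpyrimidin-2-yl in place of 4-chloro-6-methoxypyrimidin-2-yl on an amide-type nitrogen. The group that enters carries one hydrogen-bond donor where the group that leaves carries none. Within the data shown here, nothing among the measured compounds shows how this assay responds to such a change on the amide-type nitrogen. The step of a number 7.2 percentage points lower from compound 1 to compound 4 (within the scatter) is therefore expected to stay within the scatter, with a slight lean towards less inhibition. Compound 4 is estimated to give 55%, with a range from 35% to 75%.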

Compound 4, percent growth inhibition at one concentration: 49.3%
For compound 4 the middle estimate is 5.7 percentage points above the measured one; low and high end bracket the measured number.
By their numbers in this assay, from the lowest: compound 4; then compounds 1 and 2 (each within the scatter of the next); then compound 3.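

In this assay, within the data shown here, replacing 4-chloro-6-methoxypyrimidin-2-yl with 4-hydroxy-6-methylpyrimidin-2-yl on the amide-type nitrogen gives a number 12.9 percentage points lower from compound 1 to compound 4 (beyond the scatter) and so provides the first measured step at this position. It shows that this read-out can respond to a change in this group, and that this exchange, which brings in a hydrogen-bond donor and removes the chlorine, goes with less inhibition of growth. No available evidence bears on why the number falls.

The two groups differ in both their substituents, so the compounds shown leave open whether the loss of chloro or of methoxy, or the gain of hydroxy or of methyl, carries the step. They also leave open how an amine or an ethoxy group on the pyrimidine would read in this assay here.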